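The compounds below may be only part of what the source reports. "The series", "measured", "known", "first", "only" and "open" are said of these compounds alone.

In a functional assay on UACC-62 cells (Homo sapiens) for inhibition (on this read-out lower numbers stand for stronger inhibition of growth and higher numbers for weaker inhibition of growth), three compounds have been measured so far. Compound 1 (`COc1cc(/C=C/C(=O)c2cccc(-n3cc(-c4ccccc4)[nH]c3=O)c2)ccc1O`) gives 2010 nM, compound 2 (`O=C(/C=C/c1cccc(O)c1)c1cccc(-n2cc(-c3ccccc3)[nH]c2=O)c1`) gives 3650 nM, and compound 3 (`O=C(/C=C/c1cccc(O)c1)c1cccc(-n2cc(-c3ccc(Cl)cc3)[nH]c2=O)c1`) gives 1850 nM. Compound 3 therefore stands among values that all lie within the scatter of one another, and no order among the three can be claimed.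

The next compound, compound 4 (`COc1cc(/C=C/C(=O)c2cccc(-n3cc(-c4ccc(Cl)cc4)[nH]c3=O)c2)ccc1O`), keeps the chloro group of compound 3 and carries 4-hydroxy-3-methoxyphenyl in place of 3-hydroxyphenyl on a double-bonded chain carbon bound to a double-bonded chain carbon. The same exchange has been measured once, in the opposite direction and without the chloro group, as a 1.8-fold higher number from compound 1 to compound 2 (0.26 log units; within the scatter). The other measured step, a 2.0-fold lower number from compound 2 to compound 3 (0.30 log units; within the scatter), is the introduction of the chloro group, which compound 4 shares with compound 3.

Read backwards, the first step points towards a slightly lower number in this assay, but it rests on one pair and stays within the scatter, so no clear shift is expected. The estimated change is a 1.4-fold lower number from compound 3 to compound 4 (0.15 log units; within the scatter). Compound 4 is expected at about 1300 nM, with an estimated range from 600 nM to 2900 nM.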

Compound 4, concentration for 50% growth inhibition: 2740 nM
Compound 4: the middle estimate sits 2.1-fold (0.32 log units) below what was measured; the range from low to high includes it.
By their numbers in this assay, from the lowest: compounds 3, 1, 4 and 2 (each within the scatter of the next).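

In this assay, the exchange on a double-bonded chain carbon bound to a double-bonded chain carbon can now be read with the chloro group present, as a 1.5-fold higher number from compound 3 to compound 4 (0.17 log units; within the scatter), and the chloro group can be read on the core carrying 4-hydroxy-3-methoxyphenyl, as a 1.4-fold higher number from compound 1 to compound 4 (0.13 log units; within the scatter). Each of these steps lies within the scatter, but the exchange of 3-hydroxyphenyl and 4-hydroxy-3-methoxyphenyl does not give the same result on the two cores: the same change on two cores in this assay, a 1.8-fold higher number (0.26 log units; within the scatter) from compound 1 to compound 2 and a 1.5-fold lower number (0.17 log units; within the scatter) from compound 4 to compound 3, 2.7-fold (0.43 log units) apart, beyond the scatter of two such steps. The chloro group shows the same dependence on its partner, so among these four compounds neither change can be treated as a fixed increment that simply adds to the other: the same change on two cores in this assay, a 2.0-fold lower number (0.30 log units; within the scatter) from compound 2 to compound 3 and a 1.4-fold higher number (0.13 log units; within the scatter) from compound 1 to compound 4, 2.7-fold (0.43 log units) apart, beyond the scatter of two such steps.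

The compounds shown leave open whether this gap between the two cores is special to chloro or would also appear with fluoro, bromo or trifluoromethyl on the same aromatic carbon. They also leave open how a 3-aminophenyl or 3-carboxyphenyl group on the double-bonded chain carbon would read on either core, with or without the chloro group.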